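This account rests on a few compounds, and the source may have more. Where it says the series, first, only, none or still open, it means among the compounds named here.

Compound 1 `COc1ccccc1OCC1SCCN1C(=O)CNC(C)=O` was tested in a functional assay on the whole organism for inhibition, with Cavia porcellus as the target (on this read-out higher numbers stand for an effect only at larger amounts of compound and lower numbers for an effect already at smaller amounts), where compound 1 gives 40 mg/kg. That is the highest number of the three shown, though its gap to compound 3 `CCOC(=O)CC(=O)N1CC[S+]([O-])C1COc1ccccc1OC`, which gives 27 mg/kg, and its gap to compound 2 `COc1ccccc1OCC1N(C(=O)CC(=O)O)CC[S+]1[O-]`, which gives 20 mg/kg, are both within the scatter. Among the compounds with values here, the only measured step, a 1.4-fold higher number from compound 2 to compound 3 (0.13 log units; within the scatter), concerns a different part of the molecule. Compound 4 `COc1ccccc1OCC1SCCN1C(=O)CC(=O)N1CCN(C)CC1` differs from compound 1 by (4-methylpiperazin-1-yl)carbonyl in place of acetamido on a saturated chain carbon bound to a carbonyl carbon. Within the data shown here, no measured step bears on this change, and all three known numbers sit within the scatter of one another. Compound 4 is therefore expected to give about 30 mg/kg, within a range of 10 mg/kg to 90 mg/kg, meaning an expected 1.3-fold lower number from compound 1 to compound 4 (0.12 log units; within the scatter) that does not clearly exceed the scatter in either direction.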

Compound 4, dose for half-maximal effect: 27 mg/kg
The estimate for compound 4 lay 1.1-fold (0.05 log units) above the measured number; the range from low to high includes it.
By their numbers in this assay, from the lowest: compounds 2, 3, 4 and 1 (each within the scatter of the next).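

In this assay the saturated chain carbon bound to a carbonyl carbon accepts (4-methylpiperazin-1-yl)carbonyl in place of acetamido (a 1.5-fold lower number from compound 1 to compound 4 (0.17 log units; within the scatter)). This position therefore carries 9 heavy atoms, including a six-membered non-aromatic ring and 0 hydrogen-bond donors, with the number staying within the scatter of that of compound 1. Nothing available accounts for this result. From the compounds shown here alone, whether a primary amine, a carboxylic acid or a longer chain at this place would shift the number beyond the scatter remains open.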